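This account rests on a few compounds, and the source may have more. Where it says the series, first, only, none or still open, it means among the compounds named here.

Compound 2 (`COc1cc(-c2nnc(SCC(=O)c3cccc(Br)c3)n2N)cc(OC)c1OC`) is the starting point of this account. Among the compounds with values here, in a functional assay on HepG2 cells (Homo sapiens) for antiproliferative activity, read by MTT assay, with a stated time of 48 h (on this read-out higher numbers stand for weaker inhibition and lower numbers for stronger inhibition), compound 2 gives 56000 nM, which is the only number among the values shown. Within the data shown here, the one other value is a limit, and it belongs to compound 1 (`COc1cc(-c2nnc(SCC(=O)c3ccc(C)cc3)n2N)cc(OC)c1OC`), which in this assay gives only a limit, > 100000 nM. Among the measured compounds shown here, the single measured step, an at least 1.7-fold lower number from compound 1 to compound 2 (0.25 log units; that floor lies within the scatter), rests on the limit of > 100000 nM in this assay, at which 1 of the 2 values shown sits, and so sets only a floor. Compound 3 (`COc1cc(-c2nnc(SCC(=O)Nc3ccc(C)cc3)n2N)cc(OC)c1OC`) differs from compound 2 in (4-methylphenyl)amino in place of 3-bromophenyl on a carbonyl carbon. For the measured compounds named here, no measured step covers an amide here, and the 4-methylphenyl ring of compound 3 is the one carried by compound 1, which gave only a limit. Compound 3 is expected to sit near that limit, with a step of a 1.8-fold higher number from compound 2 to compound 3 (0.25 log units; within the scatter) expected. The estimate for compound 3 is 100000 nM, in a range from 40000 nM to 300000 nM.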

Compound 3, half-maximal inhibitory concentration: > 100000 nM
Compound 3: a limit, no number; the forecaster's own chance of this, stated with the estimate: 45%; the middle value sits exactly at the limit.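

In this assay, moving from the 3-bromophenyl ketone to the amide carrying (4-methylphenyl)amino on the carbonyl carbon gives an at least 1.7-fold higher number from compound 2 to compound 3 (0.25 log units; that floor lies within the scatter), so this change gives no number and shows no gain, while its floor does not establish a loss. Compound 3 gives only a limit, as compound 1 does, and the step between these two compounds cannot be read. With an amide now tried at this position as well as a ketone, compound 2 remains the only compound with a number, and the other two rest at one limit: the limit of > 100000 nM in this assay, at which 2 of the 3 values shown sit.

The compounds shown leave open whether the amide or the 4-methylphenyl ring goes with the limit, since no pair separates the two. They also leave open how a (3-bromophenyl)amino group on this carbonyl carbon, or a longer chain in front of the carbonyl, would read.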